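This account rests on a few compounds, and the source may have more. Where it says the series, first, only, none or still open, it means among the compounds named here.

Compound 1 `COc1ccc2occ(CSC(=S)N3CCCCC3)c(=O)c2c1` was tested in a functional assay on HeLa cells (Homo sapiens) for antiproliferative activity, read by MTT assay, with a stated time of 72 h (on this read-out lower numbers stand for stronger inhibition and higher numbers for weaker inhibition), where compound 1 gives 3500 nM. Compound 3 `O=c1c(CSC(=S)N2CCOCC2)coc2cc(Cl)ccc12` gives 2000 nM in this assay, a value within the usual scatter of that of compound 1, so the two cannot be ranked against each other. Compound 2 `O=c1cc(CSC(=S)N2CCCCC2)oc2cc(Cl)ccc12` gives > 25000 nM in this assay, which is a limit of the assay rather than a number. Of the two numbers shown, compound 1 has the higher one. Compound 4 `COc1ccc2occ(CSC(=S)N3CCCC3)c(=O)c2c1` differs from compound 1 by pyrrolidin-1-yl in place of piperidin-1-yl on a thiocarbonyl carbon. Within the data shown here, no measured pair here shares this change, so its effect is unknown. The step expected is no change at the digits printed from compound 1 to compound 4 (within the scatter), none beyond the scatter in either direction. Compound 4 is therefore estimated at 3500 nM, with a range from 1500 nM to 9000 nM.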

Compound 4, half-maximal inhibitory concentration: 12100 nM
Compound 4: middle estimate off by 3.5-fold (0.54 log units), on the low side; measured number above the stated range.
By their numbers in this assay, from the lowest: compounds 3 and 1 (each within the scatter of the next); then compound 4. At a limit, above all of these: compound 2.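

In this assay, the ring on the thiocarbonyl carbon turns out to matter: pyrrolidin-1-yl in place of piperidin-1-yl brings a 3.5-fold higher number from compound 1 to compound 4 (0.54 log units; beyond the scatter), which means weaker inhibition. Among these compounds, this is the first step measured at this position, and it shows that going from a six-membered to a five-membered ring here is enough to register beyond the usual scatter. Nothing shown explains why this step occurs. Going by these compounds, it remains open how an open-chain group such as diethylamino, or a piperazine with its free amine, would behave on that carbon with the core of compound 1.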